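The compounds below may be only part of what the source reports. "The series", "measured", "known", "first", "only" and "open" are said of these compounds alone.

Among the compounds with values here, the compounds measured so far in a functional assay on Ehrlich cells (Mus musculus) for cytotoxicity, read by trypan blue exclusion (a lower number here means a stronger inhibitor, a higher number a weaker inhibitor), are few. Compound 1, `Cc1c(C(=O)N=[N+]=[N-])[n+]([O-])c2cc(Cl)ccc2[n+]1[O-]`, gives > 100 ug/mL, which is a limit of the assay and not a number. Compound 2, `COc1ccc2c(c1)[n+]([O-])c(C(=O)N=[N+]=[N-])c(C)[n+]2[O-]`, gives > 100 ug/mL, likewise a limit of the assay. Compound 3, `COc1ccc(NC(=O)Nc2c(C)[n+]([O-])c3ccc(Cl)cc3[n+]2[O-])cc1`, gives 100 ug/mL.

Compound 2 therefore stands at the limit of > 100 ug/mL in this assay, at which 2 of the 3 values shown sit, so nothing more precise than that limit is known for it. Within the data shown here, the only one-place step among the measured compounds, a step that the two limits leave unreadable from compound 1 to compound 2, has no readable size, since both of its ends are limits. Among the measured compounds shown here, compound 3 differs from the others in more than one place, so its value offers no step to compare.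

Compound 4, `COc1ccc2c(c1)[n+]([O-])c(NC(=O)OC(C)C)c(C)[n+]2[O-]`, differs from compound 2 in one place: a group of 7 heavy atoms (4 carbon, 1 nitrogen, 2 oxygen; no ring) in place of a group of 5 heavy atoms (1 carbon, 3 nitrogen, 1 oxygen; no ring), on an aromatic carbon. The new group sits on an aromatic carbon of a six-membered aromatic ring that is part of a fused or bridged system of two rings, next to the ring nitrogen and ortho to a methyl group. For the measured compounds named here, no measured step bears on this change, and compound 2 itself gives only a limit, so the expected step of a number no higher from compound 2 to compound 4 (the limit leaves the size open) in this assay rests on no measured size in either direction. With all three values at or near the same level, compound 4 is expected to give about 100 ug/mL, in a range from 30 ug/mL to 300 ug/mL, with a real chance that the assay again reports only a limit.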

Compound 4, half-maximal inhibitory concentration: > 100 ug/mL
Compound 4: no number, only a limit (the forecaster's own chance of this, stated with the estimate: 55%); the middle value lies on the limit itself.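

In this assay compound 4 gives > 100 ug/mL, which is a limit of the assay and not a number. Compound 2 also gives only a limit, so no step can be read between compound 2 and compound 4. The compounds shown leave open whether the (isopropoxycarbonyl)amino group changes the cytotoxicity at all, and how far either compound lies from the limit.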